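Three measured compounds and a second fluorine

A few compounds are considered here, and "the series" means these few. Any claim that something is new, unique, unknown or untested is made for them only; others in the source may bear on it.

Compound 1, `Oc1cc(C(F)(F)F)ccc1-c1nc(-c2ccccc2O)n(-c2ccc(Cl)cc2)n1`, gives 96.1% in a functional assay on PC-12 cells (Rattus norvegicus) for cytotoxicity, read by MTT assay, with stated times of 2 h and 24 h, tested at 10 uM; a higher number here means a stronger effect of the compound at the concentration tested, a lower number a weaker effect.
Compound 2, `COc1ccc(-n2nc(-c3ccc(C(F)(F)F)cc3O)nc2-c2ccccc2O)cc1`, gives 98.9% in this assay.
Compound 3, `Oc1cc(C(F)(F)F)ccc1-c1nc(-c2ccccc2O)n(-c2ccccc2F)n1`, gives 100% in this assay.

Compound 3 carries the highest of the three numbers, but every gap to it lies within the scatter: a number 3.9 percentage points higher from compound 1 to compound 3 (within the scatter) and a number 1.1 percentage points higher from compound 2 to compound 3 (within the scatter). The three compounds therefore cannot be told apart on these values, and no one of them can be called the most active.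

Compound 4, `Oc1cc(C(F)(F)F)ccc1-c1nc(-c2ccccc2O)n(-c2ccc(F)cc2F)n1`, differs from compound 3 by fluoro in place of hydrogen on an aromatic carbon. For the measured compounds named here, none of the measured steps changes the ring attached to the nitrogen in this way; the closest are the swaps of the whole ring, a number 3.9 percentage points higher from compound 1 to compound 3 (within the scatter) and a number 1.1 percentage points higher from compound 2 to compound 3 (within the scatter), and the change on a different ring, a number 2.8 percentage points higher from compound 1 to compound 2 (within the scatter). All three stayed within the scatter, and the numbers already sit near the top of the scale. Compound 4 is therefore expected to show no step beyond the scatter, a number 2 percentage points lower from compound 3 to compound 4 (within the scatter). The estimate for compound 4 is 98%, with a range from 90% to 100%.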

Compound 4, a percentage reported as activity, at one concentration (the size of the read-out at that concentration, not a potency): 97.9%
Estimate against measurement, compound 4: 0.1 percentage points above, within the range that was stated.
By their numbers in this assay, from the lowest: compounds 1, 4, 2 and 3 (each within the scatter of the next).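

The earlier compounds shown here changed the ring on the nitrogen only by swapping it whole, whereas here a single fluoro enters that ring on the carbon para to a large group, turning 2-fluorophenyl into 2,4-difluorophenyl. In this assay this single addition gives a number 2.1 percentage points lower from compound 3 to compound 4 (within the scatter), so a fluoro at this position leaves the read-out within the scatter. The whole-ring swaps ending in the new ring, a number 1 percentage points lower from compound 2 to compound 4 (within the scatter) and a number 1.8 percentage points higher from compound 1 to compound 4 (within the scatter), also stay within the scatter, and no measurement at hand explains these results.

As far as these compounds go, what remains open is how a group of another kind on this same carbon, such as an amine or a carboxylic acid, would read. A longer chain such as propoxy at this position is equally untested by the compounds shown here.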